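This account rests on a few compounds, and the source may have more. Where it says the series, first, only, none or still open, it means among the compounds named here.

Of the compounds shown here, three that share one core have been measured in a functional assay on A549 cells (Homo sapiens) for inhibition, read by sulforhodamine B assay, with a stated time of 48 h; on this read-out higher numbers stand for weaker inhibition of growth and lower numbers for stronger inhibition of growth. Compound 1 (`COc1ccc(/C=C/C(=O)C(=Cc2ccc(O)cc2)C(=O)/C=C/c2ccc(OC)c(OC)c2)cc1OC`) gives 420 nM, compound 2 (`COc1ccc(OC)c(C=C(C(=O)/C=C/c2ccc(O)c(OC)c2)C(=O)/C=C/c2ccc(O)c(OC)c2)c1`) gives 670 nM and compound 3 (`COc1cc(/C=C/C(=O)C(=Cc2ccc(OC)c(OC)c2)C(=O)/C=C/c2ccc(O)c(OC)c2)ccc1O`) gives 430 nM. All three values lie within the usual scatter of one another, so compound 3 sits among its neighbours and cannot be ranked against them.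

Compound 4 (`CCc1ccc(C=C(C(=O)/C=C/c2ccc(O)c(OC)c2)C(=O)/C=C/c2ccc(O)c(OC)c2)cc1`) keeps the rest of compound 3 but carries 4-ethylphenyl in place of 3,4-dimethoxyphenyl on a double-bonded chain carbon bound to a double-bonded chain carbon. Within the data shown here, only one measured step touches this place: a 1.6-fold lower number from compound 2 to compound 3 (0.19 log units; within the scatter). Among the measured compounds shown here, that step swaps one dimethoxyphenyl group for another, and no measured compound carries 4-ethylphenyl here, so the evidence is indirect. The expectation in this assay is therefore no change beyond the scatter, with a 1.2-fold higher number from compound 3 to compound 4 (0.07 log units; within the scatter) as the estimated step. For compound 4 the estimate is 500 nM, with an expected range of 200 nM to 1300 nM.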

Compound 4, concentration for 50% growth inhibition: 550 nM
Compound 4: middle estimate off by 1.1-fold (0.04 log units), on the low side, and the stated range covers the measured number.
By their numbers in this assay, from the lowest: compounds 1, 3, 4 and 2 (each within the scatter of the next).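

Putting 4-ethylphenyl at this place, on a double-bonded chain carbon bound to a double-bonded chain carbon, takes away the ring oxygens, going from 2 hydrogen-bond acceptors in the group to 0, yet this assay shows a 1.3-fold higher number from compound 3 to compound 4 (0.11 log units; within the scatter) and no change that can be read. Measured against the other dimethoxyphenyl group, the same replacement gives a 1.2-fold lower number from compound 2 to compound 4 (0.09 log units; within the scatter) and again stays level. Among these compounds, then, the methoxy groups on this ring are not required for growth inhibition in this range, and nothing measured on these compounds helps explain that result.

On these data alone, it remains open whether a ring carrying an amine or a carboxylic acid in place of 4-ethylphenyl would stay in the same range. The same question applies to a longer chain than ethyl on this ring.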